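Swapping 4-aminocyclohexyl for 1-phenylethyl on the ring nitrogen

The source may hold more compounds than are shown below. What is called first, only, known or untested is meant among the compounds shown, and "the series" means these compounds.

Compound 1, `O=C(NCc1ccc(F)cc1)c1nc(Br)c2cccnc2c1NCc1ccccc1`, in a functional assay on MDA-MB-435 cells (Homo sapiens) for cytotoxicity, read by MTT assay, with a stated time of 72 h; a higher number here means a weaker inhibitor, a lower number a stronger inhibitor: > 20000 nM, a limit of the assay.
Compound 2, `C[C@@H](Nc1c(C(=O)NCc2ccc(F)cc2)nc(Br)c2cccnc12)c1ccccc1`, in this assay: > 20000 nM, a limit of the assay.
Compound 3, `N[C@H]1CC[C@H](Nc2c(C(=O)NCc3ccc(F)cc3)nc(Br)c3cccnc23)CC1`, in this assay: 6000 nM.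

For the measured compounds named here, compound 3 holds the only true number in this set; the two other values are limits, as the limit of > 20000 nM in this assay, at which 2 of the 3 values shown sit, records. The step to compound 3 from compound 1 is an at least 3.3-fold lower number from compound 1 to compound 3 (0.52 log units; beyond the scatter), and from compound 2 it is an at least 3.3-fold lower number from compound 2 to compound 3 (0.52 log units; beyond the scatter), so the 4-aminocyclohexyl group marks the one measurable improvement shown.

Compound 4, `C[C@H](Nc1c(C(=O)NCc2ccc(F)cc2)nc(Br)c2cccnc12)c1ccccc1`, reverses that move: 1-phenylethyl in place of 4-aminocyclohexyl on a nitrogen on an aromatic ring. Compound 4 carries the same 1-phenylethyl group as compound 2, differing from it only in the configuration of the single stereocentre. Since compound 2 sits at the limit of the assay, compound 4 is expected to lose what compound 3 gained, with a 4.2-fold higher number from compound 3 to compound 4 (0.62 log units; beyond the scatter) as the expected step. Compound 4 is therefore estimated at 25000 nM, within 12000 nM to 60000 nM, most likely reported only as a limit.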

Compound 4, half-maximal inhibitory concentration: > 20000 nM
Compound 4 ended at the assay's limit (the forecaster's own chance of this, stated with the estimate: 75%); the middle value is on the limit's open side.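

Compound 4, with the other drawn configuration of the 1-phenylethyl group, gives > 20000 nM, which is a limit of the assay and not a number. The 1-phenylethyl group therefore stays at the limit in both drawn forms, and the change away from 4-aminocyclohexyl on the ring nitrogen in this assay is an at least 3.3-fold higher number from compound 3 to compound 4 (0.52 log units; beyond the scatter). The steps joining compound 4 to compound 1 and to compound 2 cannot be read, the pair that differs only in configuration included, and the reason is this: the limit of > 20000 nM in this assay, at which 3 of the 4 values shown sit.

From the compounds shown here alone, whether the amine or the saturated ring of the 4-aminocyclohexyl group goes with the lower number stays open. A plain cyclohexyl group, or a shorter chain such as 2-aminoethyl, on the same nitrogen would separate the two.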